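The compounds below may be only part of what the source reports. "The series", "measured", "known", "first", "only" and "open" are said of these compounds alone.

In a functional assay on CCRF-CEM cells (Homo sapiens) for inhibition (on this read-out higher numbers stand for weaker inhibition and lower numbers for stronger inhibition), compound 1 `Cn1cc(C#N)c2ccc(Nc3ncc(-c4ccccc4)o3)cc21` gives 8000 nM and compound 3 `Cn1cc(C#N)c2ccc(Nc3ncc(-c4cccc(CNC(=O)c5ccccc5)c4)o3)cc21` gives 5300 nM, two values within the scatter of each other. Compound 2 `Cc1cccc(-c2cnc(Nc3ccc4c(C#N)cn(C)c4c3)o2)c1` gives > 10000 nM, which is a limit of the assay and not a number. Compound 4 `Cn1cc(C#N)c2ccc(Nc3ncc(-c4cccc(CNC(=O)c5ccc6ccccc6c5)c4)o3)cc21` differs from compound 3 at one place: naphthalen-2-yl in place of phenyl on a carbonyl carbon. For the measured compounds named here, no measured step changes the group on this carbonyl carbon. The closest evidence comes from the steps that introduce the amide, a 1.5-fold lower number from compound 1 to compound 3 (0.18 log units; within the scatter) and an at least 1.8-fold lower number from compound 2 to compound 3 (0.27 log units; that floor lies within the scatter), and neither is shown to exceed the scatter. The expected step in this assay is therefore a 1.2-fold lower number from compound 3 to compound 4 (0.07 log units; within the scatter), with no change beyond the scatter anticipated. For compound 4 the estimated value is 4500 nM, with an expected range of 1500 nM to 10000 nM.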

Compound 4, half-maximal inhibitory concentration: 4400 nM
Compound 4: the middle estimate sits 1.0-fold (0.01 log units) above what was measured; the range from low to high includes it.
By their numbers in this assay, from the lowest: compounds 4, 3 and 1 (each within the scatter of the next). At a limit, above all of these: compound 2.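

At the carbonyl carbon, naphthalen-2-yl in place of phenyl gives a 1.2-fold lower number from compound 3 to compound 4 (0.08 log units; within the scatter) in this assay. For the compounds shown here, this is the first step read at this position, and the second aromatic ring of naphthalen-2-yl brings no change beyond the scatter. Compound 2 stays a limit and not a number, so it adds no size of step here: the limit of > 10000 nM in this assay, at which 1 of the 4 values shown sits.

As far as these compounds go, whether an amine or a carboxylic acid on this aromatic group would move the number beyond the scatter remains open. The same holds for a longer chain in place of the aromatic group.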